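The source may report more compounds than this note shows. Statements on the series, on what has been measured and on what is new or still open speak of the compounds shown alone.

Measured so far, in a functional assay on BV-2 cells (Mus musculus) for inhibition, read by ELISA, tested at 10 uM; on this read-out lower numbers stand for a stronger effect and higher numbers for a weaker effect at the one concentration tested:

compound 1 `O=C1COCCN1c1ccc(/N=C\c2c[nH]c3ccccc23)cc1` gives 91.2%;
compound 2 `O=C1COCCN1c1ccc(/N=C\c2cn(C(=O)c3ccccc3)c3ccccc23)cc1` gives 258%.

For the measured compounds named here, compound 2 stands highest of these two numbers, and the one step measured, a number 166.8 percentage points higher from compound 1 to compound 2 (beyond the scatter), lies beyond the scatter. Compound 3 `O=C1COCCN1c1ccc(/N=C\c2cn(C(=O)c3ccc(Cl)cc3)c3ccccc23)cc1` differs from compound 2 by chloro in place of hydrogen on an aromatic carbon. Going by the values given here, no measured step bears on this kind of change: the only step known concerns a benzoyl in place of hydrogen on an aromatic nitrogen, and says nothing about a chloro on a six-membered aromatic ring of carbon only. With nothing to go on but the value of compound 2, the expectation is a step of no size beyond the scatter, in either direction. In this assay compound 3 is therefore estimated to give about 250%, with a range from 180% to 320%. The estimated step of a number 8 percentage points lower from compound 2 to compound 3 (within the scatter) is expected to stay within the usual scatter.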

Compound 3, a percentage reported as activity, at one concentration (the size of the read-out at that concentration, not a potency): 76.5%
Estimate against measurement, compound 3: 173.5 percentage points above; measured number below the stated range.
By their numbers in this assay, from the lowest: compound 3; then compound 1; then compound 2.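

In this assay, the place on the benzoyl ring para to a large group turns out to matter greatly: chloro in place of hydrogen there gives a number 181.5 percentage points lower from compound 2 to compound 3 (beyond the scatter) and so removes the whole rise seen with plain benzoyl. With hydrogen on the aromatic nitrogen as the starting point, (4-chlorophenyl)carbonyl gives a number 14.7 percentage points lower from compound 1 to compound 3 (beyond the scatter) and thus shows that, among these three compounds, a group on that nitrogen does not always raise the number, since its direction changes with a single chlorine atom. Nothing measured here explains why one atom has so large an effect.

As far as these compounds go, it remains open whether fluoro, bromo, methyl or methoxy at this same place would lower the number as chloro does. Also open, from the compounds shown here alone, is whether chloro elsewhere on the ring would do the same.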